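Swapping a triazole for a butoxy chain on a nicotinic ligand

The compounds below may be only part of what the source reports. "The series", "measured", "known", "first", "only" and "open" are said of these compounds alone.

Measured so far:
compound 1 `C(=C1\CCCN=C1c1cccnc1)\c1ccc(-n2ccnn2)cc1`: 520 nM
compound 2 `Cc1cc(O)cc(C)c1/C=C1\CCCN=C1c1cccnc1`: 670 nM

In an assay on membranes from brain for displacement of a labelled ligand from Neuronal acetylcholine receptor; alpha4/beta2 (Rattus norvegicus), with a stated time of 3 h (a higher number here means a weaker inhibitor, a lower number a stronger inhibitor), compound 1 gives 520 nM, the lower of the two numbers, while compound 2 gives 670 nM; the gap between them lies within the usual scatter, so neither can be called stronger. Compound 3 `CCCCOc1ccc(/C=C2\CCCN=C2c2cccnc2)cc1` has not been measured. It differs from compound 1 by butoxy in place of 1H-1,2,3-triazol-1-yl on an aromatic carbon. Among the compounds with values here, no measured pair shows a step of this kind, so the expected step from compound 1 to compound 3 in this assay, a 1.3-fold higher number from compound 1 to compound 3 (0.13 log units; within the scatter), is taken as small and within the scatter. Compound 3 is expected to give about 700 nM, in a range from 200 nM to 2500 nM.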

Compound 3, inhibition constant: 1960 nM
For compound 3 the middle estimate is 2.8-fold (0.45 log units) below the measured one; the measured number falls inside the stated range.
By their numbers in this assay, from the lowest: compounds 1 and 2 (each within the scatter of the next); then compound 3.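

In this assay, the group on this aromatic carbon, para to a large group, clearly matters: butoxy in place of 1H-1,2,3-triazol-1-yl gives a 3.8-fold higher number from compound 1 to compound 3 (0.58 log units; beyond the scatter), a modest change. The two groups match in heavy atoms but differ in having a ring and in their hydrogen-bond acceptors, and this single pair cannot separate those differences. Nothing available explains the step.

As far as these compounds go, it remains open whether the chain or the loss of the ring counts more. Methoxy, a longer chain or an imidazole ring at this position would help to separate them.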